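This account rests on a few compounds, and the source may have more. Where it says the series, first, only, none or still open, it means among the compounds named here.

Three compounds have been measured in a functional assay on SW-620 cells (Homo sapiens) for cytotoxicity, read by MTT assay, with a stated time of 72 h; on this read-out lower numbers stand for stronger inhibition and higher numbers for weaker inhibition:
compound 1, `COc1cccc(/C=C2\CCC/C(=C\c3cccc(O)c3)C2=O)c1OC`, giving 6400 nM;
compound 2, `COc1cccc(/C=C2\CCC/C(=C\c3ccc(O)cc3)C2=O)c1OC`, for which the assay reports only a limit, > 20000 nM;
compound 3, `COc1ccc(/C=C2\CCC/C(=C\c3cccc(O)c3)C2=O)cc1OC`, giving 1900 nM.

Compound 3 gives the lowest of the two numbers measured, and its nearest neighbour is compound 1. The difference between the core of compound 1 and the core of compound 3 is not broken down here. Compound 1 and compound 2 differ by one change, (4-hydroxyphenyl in place of 3-hydroxyphenyl on a double-bonded chain carbon bound to a double-bonded ring carbon), and that change gave an at least 3.1-fold higher number from compound 1 to compound 2 (0.49 log units; beyond the scatter). The value of compound 2 is a limit of this assay, (the limit of > 20000 nM in this assay, at which 1 of the 3 values shown sits), so the size of this step is known only as a lower bound.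

Compound 4, `COc1ccc(/C=C2\CCC/C(=C\c3ccc(O)cc3)C2=O)cc1OC`, has not yet been measured in this assay. It stands to compound 3 as compound 2 stands to compound 1: the change is the same, (4-hydroxyphenyl in place of 3-hydroxyphenyl on a double-bonded chain carbon bound to a double-bonded ring carbon), occurring for the second time among the compounds shown. On the basis of the step from compound 1 to compound 2, compound 4 is expected to give a higher number than compound 3, with an estimated step of a 4.2-fold higher number from compound 3 to compound 4 (0.62 log units; beyond the scatter) beside the earlier at least 3.1-fold higher number from compound 1 to compound 2 (0.49 log units; beyond the scatter). Compound 3 starts from a lower number, 1900 nM. Compound 4 is estimated to give 8000 nM, with a range from 3500 nM to 20000 nM.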

Compound 4, half-maximal inhibitory concentration: 7700 nM
For compound 4 the middle estimate is 1.0-fold (0.02 log units) above the measured one, within the range that was stated.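

Carried onto the core of compound 3, 4-hydroxyphenyl in place of 3-hydroxyphenyl gave in this assay a 4.1-fold higher number from compound 3 to compound 4 (0.61 log units; beyond the scatter), so the change moved the number in the same direction on both cores shown: the same change on two cores in this assay, an at least 3.1-fold higher number (0.49 log units; beyond the scatter) from compound 1 to compound 2 and a 4.1-fold higher number (0.61 log units; beyond the scatter) from compound 3 to compound 4; the limit leaves it open whether they differ

The value of compound 2 is a limit of the assay, > 20000 nM. The series therefore shows that the direction of the change carried over from one core to the other, but it does not show that the step has the same size on both, and two cores say nothing about how the change behaves on any further core.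

The compounds shown leave open whether an amine or a carboxylic acid in place of the hydroxy group on the same phenyl ring would follow this direction in this assay. From the compounds shown here alone, it is also open whether the change would carry over to a core in which an ethoxy group replaces the methoxy groups.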